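Side-chain removal in a paw-edema series: compound 4

The source may hold more compounds than are shown below. What is called first, only, known or untested is meant among the compounds shown, and "the series" means these compounds.

Measured in a functional assay on the whole organism (strain Wistar) for inhibition, with Rattus norvegicus as the target, read by paw edema, with a stated time of 1 h, at a dose of 10 mg/kg by the intraperitoneal route; a lower number here means less inhibition, a higher number more inhibition at the dose given (going by the name of the read-out):
compound 1 `Cc1ncc([N+](=O)[O-])n1CCOC(=O)c1cc(NC(=O)C(C)NC(=O)OCc2ccccc2)ccc1O`: 57.9%
compound 2 `Cc1ncc([N+](=O)[O-])n1CCOC(=O)c1cc(NC(=O)[C@H](C)NC(=O)OCc2ccccc2)ccc1O`: 58.5%
compound 3 `Cc1ncc([N+](=O)[O-])n1CCOC(=O)c1cc(NC(=O)[C@H](CCCCN)NC(=O)OCc2ccccc2)ccc1O`: 44.3%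

Compound 3 gives the lowest of the three numbers; the nearest, compound 1, is beyond the scatter above it, and compound 2 is furthest. The step of a number 0.6 percentage points higher from compound 1 to compound 2 (within the scatter) lies within the scatter, which is consistent with the fact that one of compounds 1 and 2 is drawn with a defined configuration and the other without, at the place where they differ. The step of a number 14.2 percentage points lower from compound 2 to compound 3 (beyond the scatter) is modest and beyond the scatter.

Compound 4 `Cc1ncc([N+](=O)[O-])n1CCOC(=O)c1cc(NC(=O)CNC(=O)OCc2ccccc2)ccc1O` differs from compound 3 as hydrogen in place of 4-aminobutyl on a saturated chain carbon bound to an amide-type nitrogen and a carbonyl carbon. The step from compound 2 to compound 3 bears on this change in the opposite direction, since it added the aminoalkyl chain and lowered the read-out. Removing the chain is therefore expected to raise the read-out in this assay by a modest amount, roughly back toward compounds 1 and 2, as a number 10.7 percentage points higher from compound 3 to compound 4 (beyond the scatter). Compound 4 is estimated at 55%, within 42% to 67%.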

Compound 4, a percentage reported as inhibition, in the whole organism at one dose (the size of the read-out at that dose, not a potency): 56.1%
Beside the measured number, compound 4's estimate is 1.1 percentage points below it; low and high end bracket the measured number.
By their numbers in this assay, from the lowest: compound 3; then compounds 4, 1 and 2 (each within the scatter of the next).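

In this assay hydrogen in place of 4-aminobutyl gives a number 11.8 percentage points higher from compound 3 to compound 4 (beyond the scatter) and so reverses the lower read-out of the compound carrying that chain. Hydrogen in place of methyl gives a number 2.4 percentage points lower from compound 2 to compound 4 (within the scatter) and a number 1.8 percentage points lower from compound 1 to compound 4 (within the scatter) and so leaves hydrogen and methyl indistinguishable at this saturated chain carbon. Nothing on hand accounts for the effect of the 4-aminobutyl chain.

Open, going by these compounds, is whether the terminal amine or the chain itself goes with the lower read-out. A plain butyl chain or a carboxylic acid at the chain end would separate the two.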